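A few compounds are considered here, and "the series" means these few. Any claim that something is new, unique, unknown or untested is made for them only; others in the source may bear on it.

Compound 1, whose structure is `O=C(O)CCC/C=C\C[C@H]1/C(=N/OC(c2ccccc2)c2ccccc2)CC[C@@H]1NS(=O)(=O)c1ccc(Cl)cc1`, and compound 2, whose structure is `O=C(O)CCC/C=C\C[C@H]1/C(=N/OC(c2ccccc2)c2ccccc2)CC[C@@H]1NS(=O)(=O)c1ccc(F)cc1`, share a core and differ only at one aromatic carbon: fluoro in place of chloro on an aromatic carbon. In a functional assay (plasma) for inhibition, with Homo sapiens as the target (on this read-out higher numbers stand for weaker inhibition and lower numbers for stronger inhibition), compound 1 gives 17000 nM, and in this assay compound 2 gives 17000 nM, so that the step of no change at the digits printed from compound 1 to compound 2 (within the scatter) leaves the read-out where it was. Compound 3, with structure `O=C(O)CCC/C=C\C[C@@H]1[C@H](O)CC[C@H]1NS(=O)(=O)c1ccc(Cl)cc1`, is built on a different core; how that core differs from the core of compound 1 is not broken down here. In this assay compound 3 gives 2200 nM, the lowest number among the three measured compounds, and its distance from compound 1 and from compound 2 lies beyond the usual scatter of the read-out.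

Compound 4, with structure `O=C(O)CCC/C=C\C[C@@H]1[C@H](O)CC[C@H]1NS(=O)(=O)c1ccc(F)cc1`, has not yet been measured. It is related to compound 3 by the same change that turns compound 1 into compound 2: fluoro in place of chloro on an aromatic carbon. The place of the exchange is worded identically in both pairs, so the change counts as the same one made on another core. Because the step of no change at the digits printed from compound 1 to compound 2 (within the scatter) produced no change beyond the scatter, the step from compound 3 to compound 4 is expected to be of about that size, no change at the digits printed from compound 3 to compound 4 (within the scatter). On that basis compound 4 is estimated to give 2200 nM in this assay, with the expected range running from 1100 nM to 4400 nM.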

Compound 4, half-maximal inhibitory concentration: 6000 nM
Compound 4: the middle estimate sits 2.7-fold (0.44 log units) below what was measured, outside the stated range (above it).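

In this assay, the exchange of chloro for fluoro on an aromatic carbon, para to a large group, gives a 2.7-fold higher number from compound 3 to compound 4 (0.44 log units; beyond the scatter), while the same exchange on the other core gave no change at the digits printed from compound 1 to compound 2 (within the scatter). The change from 4-chlorophenyl to 4-fluorophenyl therefore did not carry over from one core to the other as a step of the same size, and the two steps can be told apart: the same change on two cores in this assay, no change at the digits printed (within the scatter) from compound 1 to compound 2 and a 2.7-fold higher number (0.44 log units; beyond the scatter) from compound 3 to compound 4, 2.7-fold (0.44 log units) apart, beyond the scatter of two such steps With only these two pairs, this does not show which feature of the two cores separates the steps, nor which of the two steps, if either, would be the better guide on a further core in this series.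

The compounds shown leave open how other groups at the same aromatic carbon, such as a hydrogen, a methoxy group, a trifluoromethyl group or a nitrile, would behave on each of the two cores, and whether their steps would also part from one core to the other. They also leave open whether a gap of this kind would appear in a read-out other than this one, or for a halogen such as bromo.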